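Chain terminus swap on the shared core

The source may report more compounds than this note shows. Statements on the series, on what has been measured and on what is new or still open speak of the compounds shown alone.

Compound 1 `NCCCCOc1ccc2c(=O)c(-c3ccc(O)cc3)coc2c1` carries a saturated ether chain ending in an amino group on the shared core. In an assay (Cricetulus griseus) for inhibition of aldehyde dehydrogenase, mitochondrial (Homo sapiens) (on this read-out higher numbers stand for weaker inhibition and lower numbers for stronger inhibition), compound 1 gives 250 nM, the lowest of the two numbers at hand. Compound 2 `CCCCC(Oc1ccc2c(=O)c(-c3ccc(O)cc3)coc2c1)C(=O)OCC`, with an ester-bearing branched ether, gives in this assay 4500 nM, a gap to compound 1 that lies beyond the scatter. For compound 3 `O=C(O)CCCCCCCCCCCCCCCOc1ccc2c(=O)c(-c3ccc(O)cc3)coc2c1` the read-out in this assay is a limit of the assay rather than a number, > 9000 nM; one of the three values sits at that limit (the limit of > 9000 nM in this assay, at which 1 of the 3 values shown sits).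

Compound 4 `C=CCCCCOc1ccc2c(=O)c(-c3ccc(O)cc3)coc2c1` is the single-point variation of compound 1 in this set: vinyl in place of amino on a saturated chain carbon, four bonds along the chain from an oxygen on an aromatic ring. For the measured compounds named here, no step between two measured compounds covers this change, so the size of the step can only be anticipated. Compound 2 and compound 3, which also lack the amino terminus, both show weaker inhibition, but each differs from compound 1 in more than one place, so they give only a loose pointer in the direction of a higher number.

For compound 4 in this assay a value of 1500 nM is expected, within a range from 400 nM to 6000 nM; the step this implies is estimated as a 6.0-fold higher number from compound 1 to compound 4 (0.78 log units; beyond the scatter), toward weaker inhibition.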

Compound 4, half-maximal inhibitory concentration: 150 nM
Compound 4: middle estimate off by 10-fold (1.00 log units), on the high side, outside the stated range (below it).
By their numbers in this assay, from the lowest: compounds 4 and 1 (each within the scatter of the next); then compound 2. At a limit, above all of these: compound 3.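

In this assay, vinyl in place of amino on a saturated chain carbon, four bonds along the chain from an oxygen on an aromatic ring, gives a 1.7-fold lower number from compound 1 to compound 4 (0.22 log units; within the scatter) and so shows that this position tolerates the loss of the amino terminus without a change beyond the scatter. The swap removes the nitrogen with its hydrogen-bond donor and hydrogen-bond acceptor and brings in two carbons with a double bond outside aromatic rings, yet this pair gives no sign that the read-out depends on any of these features. This makes the amino group one workable terminus at this position rather than a necessary one, and nothing on record bears on why the two termini read alike.

Still open, going by these compounds, is how other termini on a chain of this length would read, such as a hydroxyl, a carboxylic acid or a plain saturated alkyl end. Also open, on these data alone, is the effect of chain length on its own, which a longer chain ending in amino or vinyl would address.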